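The source may hold more compounds than are shown below. What is called first, only, known or untested is meant among the compounds shown, and "the series" means these compounds.

Of the compounds shown here, three built on one shared core have been tested in a functional assay on HL-60 cells (Homo sapiens) for cytotoxicity, read by MTT assay, with a stated time of 24 h; a higher number here means a weaker inhibitor, a lower number a stronger inhibitor. Compound 1 `C#CCOc1c(Br)cc(Br)cc1Oc1ccc(Br)cc1Br` gives 29.7 ug/mL. Compound 2 `BrCCCOc1c(Br)cc(Br)cc1Oc1ccc(Br)cc1Br` gives 29.9 ug/mL in this assay. Compound 3 `CCOC(=O)C(C)Oc1c(Br)cc(Br)cc1Oc1ccc(Br)cc1Br` gives 35.7 ug/mL in this assay; its number is the largest of the three shown, yet its steps to the other two, a 1.2-fold higher number from compound 1 to compound 3 (0.08 log units; within the scatter) and a 1.2-fold higher number from compound 2 to compound 3 (0.08 log units; within the scatter), both fall within the scatter, as does a 1.0-fold higher number from compound 1 to compound 2 (0.00 log units; within the scatter). The three therefore sit together, and none can be called stronger or weaker than another.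

Compound 4 `BrCCOc1c(Br)cc(Br)cc1Oc1ccc(Br)cc1Br` has not yet been measured. It differs from compound 3 in a single place: 2-bromoethyl in place of 1-(ethoxycarbonyl)ethyl on an oxygen on an aromatic ring. Among the compounds with values here, two measured steps bear on this change. The step of a 1.2-fold higher number from compound 2 to compound 3 (0.08 log units; within the scatter) exchanged a 3-bromopropyl for the 1-(ethoxycarbonyl)ethyl, the reverse sense of the present change with a related bromine-bearing chain, and moved the number by an amount inside the scatter. The step of a 1.0-fold higher number from compound 1 to compound 2 (0.00 log units; within the scatter) placed a bromine-bearing chain at the same oxygen with no shift beyond the scatter. Nothing among these compounds points to a large move in either direction. The expected step is a 1.2-fold lower number from compound 3 to compound 4 (0.08 log units; within the scatter), no larger than the scatter. Compound 4 is therefore estimated at 30 ug/mL, with a likely range from 17 ug/mL to 52 ug/mL.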

Compound 4, half-maximal inhibitory concentration: 26.2 ug/mL
Compound 4: middle estimate off by 1.1-fold (0.06 log units), on the high side, within the range that was stated.
By their numbers in this assay, from the lowest: compounds 4, 1, 2 and 3 (each within the scatter of the next).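

Exchanging the 1-(ethoxycarbonyl)ethyl on this oxygen, with 7 heavy atoms and 2 hydrogen-bond acceptors, for the 2-bromoethyl, with 3 heavy atoms and no acceptors, gives a 1.4-fold lower number from compound 3 to compound 4 (0.13 log units; within the scatter) in this assay and so stays inside the scatter even though much of the group is replaced. The two other comparisons extend this result: trimming the 3-bromopropyl to 2-bromoethyl gives a 1.1-fold lower number from compound 2 to compound 4 (0.06 log units; within the scatter) and replacing the propargyl with 2-bromoethyl gives a 1.1-fold lower number from compound 1 to compound 4 (0.05 log units; within the scatter) in this assay with neither step leaving the scatter. All four groups on this oxygen therefore sit together in this assay, which shows that neither the ester nor the length of the bromine-bearing chain separates these compounds, and no measurement shown here explains this lack of separation.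

As far as these compounds go, whether a carboxylic acid or an amine on this oxygen, or a chain longer than the 3-bromopropyl, would move the number beyond the scatter remains open. Also open, from the compounds shown here alone, is what would follow from removing a bromine from the shared core, which is identical in all four compounds.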